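Removing a carbonyl from compound 2

The source may hold more compounds than are shown below. What is called first, only, known or untested is meant among the compounds shown, and "the series" means these compounds.

In a functional assay on RKO cells (Homo sapiens) for inhibition, read by MTT assay, with a stated time of 48 h (a higher number here means a weaker inhibitor, a lower number a stronger inhibitor), compound 2 (`COc1ccc(N(C)c2nc(C)nc3ccccc23)cc1C(=O)OCC[Se]C#N`) gives 2390 nM, the highest of the three numbers and so the weakest inhibitor measured. Compound 1 (`COc1ccc(N(C)c2nc(C)nc3ccccc23)cc1OCCC[Se]C#N`) gives 799 nM and compound 3 (`COc1ccc(N(C)c2nc(C)nc3ccccc23)cc1C(=O)OCCCC[Se]C#N`) gives 1020 nM, two values within the scatter of each other. Compound 4 (`COc1ccc(N(C)c2nc(C)nc3ccccc23)cc1OCC[Se]C#N`) is still unmeasured. Its change from compound 2 is a group of 6 heavy atoms (3 carbon, 1 nitrogen, 1 oxygen, 1 selenium; no ring) in place of a group of 8 heavy atoms (4 carbon, 1 nitrogen, 2 oxygen, 1 selenium; no ring), on an aromatic carbon, ortho to a methoxy group, so the carbonyl is lost while the chain length stays. For the measured compounds named here, two measured steps bear on this. The closest comparison for losing the carbonyl is a 3.0-fold higher number from compound 1 to compound 2 (0.48 log units; beyond the scatter), though that step also changes the chain length. Chain length alone matters too, as a 2.3-fold lower number from compound 2 to compound 3 (0.37 log units; beyond the scatter) shows, and compound 4 has a shorter chain than compound 1. A modest drop from compound 2 is therefore expected, smaller than the full gap to compound 1. The expected step is a 1.8-fold lower number from compound 2 to compound 4 (0.26 log units; within the scatter). Compound 4 is estimated at 1300 nM, with an expected range of 550 nM to 2900 nM.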

Compound 4, half-maximal inhibitory concentration: 27 nM
The estimate for compound 4 lay 48-fold (1.68 log units) above the measured number; the measured number lies below the stated range.
By their numbers in this assay, from the lowest: compound 4; then compounds 1 and 3 (each within the scatter of the next); then compound 2.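

In this assay, for the compounds shown here, the ether-linked chain proves far more sensitive to its length than the earlier compounds suggested: a 30-fold lower number from compound 1 to compound 4 (1.47 log units; beyond the scatter), and the change is only one small group in place of another on a saturated chain carbon. Compound 4 also stands well clear of both esters, with an 89-fold lower number from compound 2 to compound 4 (1.95 log units; beyond the scatter) and a 38-fold lower number from compound 3 to compound 4 (1.58 log units; beyond the scatter), which makes it the strongest inhibitor of the four. The earlier steps shown here were modest or within the scatter, so they gave no sign that this position on the aromatic carbon could move the number so far.

Nothing given here explains this sharp gain. Going by these compounds, it remains open how an ether with a single chain carbon, or an amine in place of the ether oxygen, would behave.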